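The source may report more compounds than this note shows. Statements on the series, on what has been measured and on what is new or still open speak of the compounds shown alone.

Compound 2 (`COc1ccc2nc(-c3ccc(N/C=C\C(=O)c4cc(OC)c(OC)c(OC)c4)cc3)sc2c1`) gives 12100 nM in a functional assay on A549 cells (Homo sapiens) for antiproliferative activity, read by sulforhodamine B assay, with a stated time of 48 h (a lower number here means a stronger inhibitor, a higher number a weaker inhibitor), and stands towards the upper end of the three numbers available. Compound 3 (`COc1ccc2nc(-c3ccc(N/C=C\C(=O)c4cc(OC)c(OC)c([N+](=O)[O-])c4)cc3)sc2c1`) gives 21600 nM in this assay and lies within the scatter of compound 2. Only compound 1 (`COc1ccc(C(=O)/C=C\Nc2ccc(-c3nc4cc(OC)c(OC)c(OC)c4s3)cc2C)cc1F`) at 1690 nM shows a clearly lower number than compound 2, but the two differ in more than one place, so that gap cannot be tied to any single change.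

Compound 4 (`COc1ccc2nc(-c3ccc(N/C=C\C(=O)c4cc(OC)c(OC)c(OC)c4Br)cc3)sc2c1`) has not yet been measured. Its structure departs from compound 2 by one change (bromo in place of hydrogen on an aromatic carbon), bromo in place of hydrogen on an aromatic carbon, ortho to a large group and ortho to a methoxy group. Within the data shown here, one measured step bears on this, the nitro in place of methoxy on that same ring (a 1.8-fold higher number from compound 2 to compound 3 (0.25 log units; within the scatter)), and on that evidence no step beyond the scatter is expected in this assay for the new compound. As far as these compounds go, no bromo on this ring has been measured, so the direction remains open and the range stays wide. The estimated step is small (a 1.2-fold higher number from compound 2 to compound 4 (0.06 log units; within the scatter)), with a slight lean towards a higher number. For compound 4 the expected half-maximal inhibitory concentration is 14000 nM with an estimated range from 5000 nM to 40000 nM in this assay.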

Compound 4, half-maximal inhibitory concentration: 6000 nM
Compound 4: middle estimate off by 2.3-fold (0.37 log units), on the high side, and the stated range covers the measured number.
By their numbers in this assay, from the lowest: compound 1; then compounds 4, 2 and 3 (each within the scatter of the next, the first and the last beyond it).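

In this assay, compound 4 is the only compound shown with a substituent on this carbon, which is ortho to a large group and ortho to a methoxy group, and placing bromo there in place of hydrogen gives a 2.0-fold lower number from compound 2 to compound 4 (0.30 log units; within the scatter). The position therefore accepts this single added heavy atom without a step beyond the scatter, so these numbers do not establish a direction for the change. The same holds for the other measured change on this ring, the nitro in place of methoxy (a 1.8-fold higher number from compound 2 to compound 3 (0.25 log units; within the scatter)), so neither of the two steps on this ring separates its compounds beyond the scatter, and no measured property is available to explain the bromo result.

The compounds shown leave open what a chloro, an amine or a longer alkoxy chain on this same carbon would give, and whether any of these would produce a step beyond the scatter. They also leave open whether bromo on this carbon would give a similar step on the core of compound 1, which differs from compound 2 in more than one place.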